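Series notes: swapping the chain link at the two-nitrogen position

This account rests on a few compounds, and the source may have more. Where it says the series, first, only, none or still open, it means among the compounds named here.

Compound 1 `Nc1nc(O)nc2c1nc(O)n2Cc1ccccc1` is the parent of the set. In a functional assay (spleen, spleen) for activation, with Mus musculus as the target (a lower number here means that less compound is needed, a higher number that more compound is needed for the effect), compound 1 gives 0.1 uM. Compound 2 `CCCCNc1nc(N)c2nc(O)n(Cc3ccccc3)c2n1` carries a butylamino in place of hydroxy on an aromatic carbon, and in this assay compound 2 gives 1 uM. The change is a 10-fold higher number from compound 1 to compound 2 (1.00 log units; beyond the scatter). Among the two measured numbers compound 2 therefore stands highest, with compound 1 as its only neighbour.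

Compound 3 `CCCCSc1nc(N)c2nc(O)n(Cc3ccccc3)c2n1` is not yet measured. It differs from compound 2 as follows: butylsulfanyl in place of butylamino on an aromatic carbon. For the measured compounds named here, the only measured step touches the same aromatic carbon, but it exchanged hydroxy for butylamino, not the link between the chain and the ring, so it gives no direct read on butylsulfanyl in place of butylamino. The chain length is kept. Going by the values given here, with that single step as the sole guide, the expectation for compound 3 is a change in this assay of no more than modest size, with the direction uncertain, so the step of a 1.5-fold higher number from compound 2 to compound 3 (0.18 log units; within the scatter) is estimated to stay close to the scatter. Compound 3 is thus estimated at 1.5 uM, within 0.4 uM to 6 uM.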

Compound 3, minimum effective concentration: 0.01 uM
Compound 3: middle estimate off by 150-fold (2.18 log units), on the high side, and the stated range ends above it.
By their numbers in this assay, from the lowest: compound 3; then compound 1; then compound 2.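

Notes on the link atom: at this aromatic carbon between two ring nitrogen atoms, the atom joining the chain to the ring matters far more in this assay than the opening step suggested, with butylsulfanyl in place of butylamino giving a 100-fold lower number from compound 2 to compound 3 (2.00 log units; beyond the scatter) while the count of 4 carbon in the chain stays the same. The earlier replacement of hydroxy by butylamino gave a 10-fold higher number from compound 1 to compound 2 (1.00 log units; beyond the scatter) and could have been read as a penalty for any butyl chain at this carbon, yet butylsulfanyl gives a 10-fold lower number from compound 1 to compound 3 (1.00 log units; beyond the scatter) and so goes against that reading, which means that the direction of the change from hydroxy depends on the link and not on the chain alone. The exchange also goes from 1 hydrogen-bond donor on butylamino to 0 hydrogen-bond donors on butylsulfanyl, but no measurement at hand explains the size of the step or ties it to either difference.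

Still open, as far as these compounds go, is whether a butoxy group at this carbon, with oxygen as the link, would read closer to butylsulfanyl or to butylamino in this assay and so separate the identity of the link atom from the loss of the donor. Also open, from the compounds shown here alone, is how far the sulfur-linked result carries over to a methylsulfanyl group or a longer chain, such as hexylsulfanyl.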